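Hydroxyphenyl pyridines against topoisomerase 1: a fourth isomer

This account rests on a few compounds, and the source may have more. Where it says the series, first, only, none or still open, it means among the compounds named here.

Compound 1 `Oc1ccc(-c2cc(-c3cccc(O)c3)nc(-c3cccc(O)c3)c2)cc1` gives 0% in an assay on isolated protein for inhibition of DNA topoisomerase 1 (Homo sapiens), with a stated time of 30 min, tested at 100 uM; on this read-out lower numbers stand for less inhibition and higher numbers for more inhibition at the one concentration tested (going by the name of the read-out). Compound 2 `Oc1cccc(-c2cc(-c3ccccc3O)cc(-c3cccc(O)c3)n2)c1` gives 0% in this assay, and the step of no change at the digits printed from compound 1 to compound 2 (within the scatter) is flat. Among the measured compounds shown here, compound 3 `Oc1ccc(-c2cc(-c3cccc(O)c3)cc(-c3cccc(O)c3)n2)cc1` gives 0% in this assay, level with compounds 1 and 2; no step to either is computed, but the three values coincide. Compound 4 `Oc1cccc(-c2cc(-c3cccc(O)c3)nc(-c3cccc(O)c3)c2)c1` is not yet measured; it differs from compound 3 by 3-hydroxyphenyl in place of 4-hydroxyphenyl on an aromatic carbon. For the measured compounds named here, the only measured step that bears on it, no change at the digits printed from compound 1 to compound 2 (within the scatter), also swaps one hydroxyphenyl isomer for another and stays within the scatter, and none of the three measured compounds shows inhibition. The step of no change at the digits printed from compound 3 to compound 4 (within the scatter) is therefore expected to stay within the scatter. Compound 4 is estimated at 0%, between 0% and 10%.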

Compound 4, a percentage reported as inhibition, at one concentration (the size of the read-out at that concentration, not a potency): 0%
For compound 4 middle estimate and measured number coincide at the digits printed; measured number inside the range.
By their numbers in this assay, from the lowest: compounds 1, 2, 3 and 4 (each within the scatter of the next).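

Exchanging 4-hydroxyphenyl for 3-hydroxyphenyl on the aromatic carbon next to the ring nitrogen gives no change at the digits printed from compound 3 to compound 4 (within the scatter) in this assay, so this position now has a measured step. At a different aromatic carbon of the core, the same exchange gives no change at the digits printed from compound 1 to compound 4 (within the scatter), and 3-hydroxyphenyl in place of 2-hydroxyphenyl gives no change at the digits printed from compound 2 to compound 4 (within the scatter), so no hydroxyphenyl exchange shown separates these compounds. Nothing on hand accounts for the uniform readings. On these data alone, whether an amine or a carboxylic acid in place of the hydroxyl would give any inhibition remains open.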